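A Second Fluorine on the Sulfonyl Arm

The compounds below may be only part of what the source reports. "The series", "measured", "known", "first", "only" and "open" are said of these compounds alone.

Compound 2 `Cn1c(S(=O)(=O)Cc2ccc(F)cc2)nc(-c2ccc(F)cc2)c1-c1ccc(F)cc1` carries a 4-fluorobenzyl group on its sulfonyl sulfur. In an ADME assay on S9 fraction from liver (Homo sapiens) for metabolic stability (a lower number here means that the compound disappears faster, a higher number that the compound lasts longer), compound 2 reaches only a limit of the assay, < 0.0417 h. Its closest measured relative, compound 1 `Cn1c(S(=O)(=O)Cc2ccccc2)nc(-c2ccccc2)c1-c1ccccc1`, lacks the fluorine atoms, and in this assay compound 1 gives 0.0333 h, a number that can be read. Compound 3 `Cn1c(S(=O)(=O)C(F)c2ccc(F)cc2)nc(-c2ccccc2)c1-c1ccccc1`, with fluoro(4-fluorophenyl)methyl in place of benzyl, also ends at a limit in this assay, < 0.0417 h. The step that the limit leaves unreadable from compound 1 to compound 3 is therefore not readable, a consequence of the limit of < 0.0417 h in this assay, at which 2 of the 3 values shown sit.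

Compound 4 `Cn1c(S(=O)(=O)C(F)(F)c2ccc(F)cc2)nc(-c2ccc(F)cc2)c1-c1ccc(F)cc1` is compound 2 with one change: difluoro(4-fluorophenyl)methyl in place of 4-fluorobenzyl on a sulfonyl sulfur. For the measured compounds named here, the only measured step at the same sulfonyl sulfur, a step that the limit leaves unreadable from compound 1 to compound 3, runs into the limit, so its size is unknown and it offers no direction. Going by the values given here, no other pair differs in this place alone. What the numbers do show is that all three compounds disappear quickly in this assay and two of them sit at the limit. Compound 4 is therefore expected to behave alike, with an expected step that the limit leaves unreadable from compound 2 to compound 4 that is not beyond the scatter. The estimate for compound 4 is 0.03 h, between 0.01 h and 0.08 h, and most likely this assay will again report only a limit.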

Compound 4, half-life: > 1.5 h
Compound 4: no number, only a limit; the forecaster's own chance of this, stated with the estimate: 70%; at least 50-fold (1.69 log units) between middle value and limit.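

For the compounds shown here, at the sulfonyl sulfur, difluoro(4-fluorophenyl)methyl in place of 4-fluorobenzyl brings an at least 35-fold higher number from compound 2 to compound 4 (1.55 log units; beyond the scatter) in this assay, and this is the first step at this position that can be read. The other steps at this place cannot be read, so until now the compounds gave no direction here, whereas this single change moves a compound from one end of the measured range to the other. Compound 4 ends at a limit, so this step shows a minimum and the full size of the change remains unknown: the limit of > 1.5 h in this assay, at which 1 of the 4 values shown sits.

Going by these compounds alone, the change is seen only on the fluorinated compound 2, so it remains open whether the same replacement would have a similar effect on compound 1, which lacks the fluorine atoms on its other rings. Also open, on these data alone, is how the sulfonyl position would respond to a group of a different kind, such as an amine or a longer chain, and whether the large step depends on the fluorine atoms on the carbon bound to sulfur or would also appear with other groups there.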